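The source may report more compounds than this note shows. Statements on the series, on what has been measured and on what is new or still open speak of the compounds shown alone.

Going by the values given here, in a functional assay on SW-620 cells (Homo sapiens) for inhibition, read by sulforhodamine B assay, with a stated time of 48 h (a lower number here means a stronger inhibitor of growth, a higher number a weaker inhibitor of growth), compound 3 `O=CN1CCN(c2ccc(Cl)cc2)C1=S` gives 18000 nM, the highest number among the three compounds measured so far. Compound 1 `N#C/C(=C\N1CCN(C(=O)c2ccco2)C1=S)C(=O)Nc1ccc(Cl)cc1` gives 17300 nM, which lies within the scatter of compound 3. Among the compounds with values here, compound 2 `N#C/C(=C\N1CCN(C(=O)c2ccco2)C1=S)C(=O)c1ccccc1` gives 5900 nM, the only number that stands beyond the scatter of compound 3. Within the data shown here, the single step between measured compounds that differ in one place runs a 2.9-fold lower number from compound 1 to compound 2 (0.47 log units; beyond the scatter); it concerns the group on a carbonyl carbon of a core unlike that of compound 3, and it says nothing about adding a group to the aromatic ring that compound 3 carries.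

Compound 4 `O=CN1CCN(c2ccc(Cl)c(Cl)c2)C1=S` differs from compound 3 by chloro in place of hydrogen on an aromatic carbon. Among the measured compounds shown here, no measured step bears on a change of this kind, so there is no basis for expecting a step beyond the scatter in either direction. Compound 4 is therefore expected to show a 1.2-fold lower number from compound 3 to compound 4 (0.08 log units; within the scatter), a step of no real size. The estimate for compound 4 in this assay is 15000 nM, with a range from 5000 nM to 45000 nM.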

Compound 4, concentration for 50% growth inhibition: 19400 nM
Compound 4: the middle estimate sits 1.3-fold (0.11 log units) below what was measured, and the stated range covers the measured number.
By their numbers in this assay, from the lowest: compound 2; then compounds 1, 3 and 4 (each within the scatter of the next).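

In this assay, chloro in place of hydrogen on an aromatic carbon, ortho to a chloro group and meta to a group of 8 heavy atoms, gives a 1.1-fold higher number from compound 3 to compound 4 (0.03 log units; within the scatter), so at this position the added chloro leaves no change that can be told from the scatter. Going by these compounds alone, the earlier step concerned a group on a carbonyl carbon in a different core, so this is the first reading of a change on the aromatic ring of compound 3. Nothing available explains why the step is so small.

The compounds shown leave open whether a different group at this position, such as an amine, a methoxy group or a carboxylic acid, would also leave the number in place. They also leave open whether the same added chloro would give so small a step on the aromatic ring of compound 1, whose core is different.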